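A few compounds are considered here, and "the series" means these few. Any claim that something is new, unique, unknown or untested is made for them only; others in the source may bear on it.

Measured so far in a functional assay on liver (Sus scrofa) for inhibition of squalene monooxygenase (Homo sapiens), using microsomes; on this read-out lower numbers stand for stronger inhibition and higher numbers for weaker inhibition:
- compound 1, `CCN(C/C=C/C#CC(C)(C)C)Cc1cccc(OC[Si](C)(C)c2ccc(C(N)=O)cc2)c1` — 5000 nM
- compound 2, `CCN(C/C=C/C#CC(C)(C)C)Cc1cccc(OC[Si](C)(C)c2ccc(S)cc2)c1` — 8000 nM

For the measured compounds named here, compound 2 stands at one end of these two numbers in this assay, but the only step that separates it from compound 1, a 1.6-fold higher number from compound 1 to compound 2 (0.20 log units; within the scatter), lies within the scatter, so the two compounds cannot be told apart on this read-out.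

Compound 3, `CCN(C/C=C/C#CC(C)(C)C)Cc1cccc(OC[Si](C)(C)c2ccc(C(=O)C(F)(F)F)cc2)c1`, differs from compound 2 in one place: (trifluoromethyl)carbonyl in place of sulfanyl on an aromatic carbon. Going by the values given here, the one measured step that bears on this position, a 1.6-fold higher number from compound 1 to compound 2 (0.20 log units; within the scatter), also exchanges the group on that same aromatic carbon of the shared core and stays within the scatter. Among the compounds with values here, no measured compound carries the group that enters here, so the record offers nothing beyond a single exchange at this position that left the number essentially unchanged.

On that basis the step from compound 2 to compound 3 is expected to stay within the scatter, a 1.3-fold lower number from compound 2 to compound 3 (0.12 log units; within the scatter). Compound 3 is therefore estimated at 6000 nM in this assay, with a range from 2000 nM to 20000 nM.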

Compound 3, half-maximal inhibitory concentration: 5000 nM
Compound 3: middle estimate off by 1.2-fold (0.08 log units), on the high side; the range from low to high includes it.
By their numbers in this assay, from the lowest: compounds 1, 3 and 2 (each within the scatter of the next).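

In this assay, the exchange of sulfanyl for (trifluoromethyl)carbonyl on the aromatic carbon (a 1.6-fold lower number from compound 2 to compound 3 (0.20 log units; within the scatter)) stays within the scatter, even though 6 heavy atoms enter where 1 leaves and the incoming group has 0 hydrogen-bond donors where the sulfanyl has 1. The comparison between the two carbonyl groups reads the same way: with trifluoromethyl in place of amino on the carbonyl carbon, the record shows no change at the digits printed from compound 1 to compound 3 (within the scatter) and so gives a second result in which the change at this position cannot be told apart from the scatter. Three different groups on this aromatic carbon have now been compared without any step beyond the scatter, and nothing available accounts for this flat result.

The compounds shown leave open whether any other group at this position, such as a carboxylic acid, a primary amine or a longer alkyl chain, would move the number beyond the scatter. They also leave open how the number responds to changes elsewhere, for instance at the ethyl group on the nitrogen or in the tert-butyl-capped chain, since all three compounds share these parts.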